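Methoxy in Place of Chloro: From Compound 2 to Compound 3

The source may hold more compounds than are shown below. What is called first, only, known or untested is meant among the compounds shown, and "the series" means these compounds.

Of the compounds shown here, two sharing one core have been measured in a functional assay on MOLT-4 cells (Homo sapiens) for inhibition, read by sulforhodamine B assay, with a stated time of 48 h; a lower number here means a stronger inhibitor of growth, a higher number a weaker inhibitor of growth. Compound 1 `N=C(N)c1ccc(-c2ccc(-c3cc(Cl)cc(Cl)c3)s2)cc1` gives 1180 nM in this assay. Compound 2 `N=C(N)c1ccc(-c2ccc(-c3ccc(Cl)cc3)s2)cc1F` gives 243 nM in this assay, the lower of the two numbers; the gap to compound 1 lies beyond the usual scatter, so compound 2 is the stronger inhibitor of growth of the pair. Among the compounds with values here, the two measured compounds differ from each other in more than one place, so no single-change step is available, and nothing measured yet tells how a change on the terminal ring alone moves the number.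

Compound 3 `COc1ccc(-c2ccc(-c3ccc(C(=N)N)c(F)c3)s2)cc1` has not been measured. It differs from compound 2 in one place: methoxy in place of chloro on an aromatic carbon. Within the data shown here, with no measured step of this kind to rest on, compound 3 is expected to show at most a small step, if any, within the usual scatter, estimated as a 1.6-fold higher number from compound 2 to compound 3 (0.22 log units; within the scatter). For compound 3 in this assay the estimate is 400 nM, with a range from 120 nM to 1500 nM.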

Compound 3, concentration for 50% growth inhibition: 3260 nM
For compound 3 the middle estimate is 8.2-fold (0.91 log units) below the measured one, outside the stated range (above it).
By their numbers in this assay, from the lowest: compound 2; then compound 1; then compound 3.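

In this assay, within the data shown here, methoxy in place of chloro on an aromatic carbon, para to a large group, gives a 13-fold higher number from compound 2 to compound 3 (1.13 log units; beyond the scatter), the first single-place step, and it shows that the number depends strongly on the group at this position. Of the two groups seen here, chloro goes with the stronger inhibition of growth and methoxy with the weaker, a large loss from a change of only one chlorine for one carbon and one oxygen, which adds one hydrogen-bond acceptor. No measured property of either group is at hand to account for the size of this step.

Among these compounds, with only two groups compared at this position, it remains open whether the loss is particular to methoxy or would also follow from another replacement for chloro, such as a methyl, a hydroxyl or an amine on the same carbon. Going by these compounds, it also remains open whether methoxy in place of chloro would move the number as far on a terminal ring with a different pattern of substitution, such as that of compound 1.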